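Series notes: from compound 2 to compound 4

This account rests on a few compounds, and the source may have more. Where it says the series, first, only, none or still open, it means among the compounds named here.

Compound 2 `Cc1ccccc1Nc1nc(C)c(C(=O)/C=C/c2ccc(Cl)cc2)s1` stands at a limit in a functional assay on PC-3 cells (Homo sapiens) for cytotoxicity, read by MTT assay; a higher number here means a weaker inhibitor, a lower number a stronger inhibitor: its value is > 25000 nM, a limit of the assay and not a number. Compound 1 `Cc1nc(Nc2ccc(Cl)cc2)sc1C(=O)/C=C/c1ccccc1` gives 24600 nM in this assay. Compound 3 `Cc1nc(Nc2ccc(Cl)cc2)sc1C(=O)/C=C/c1ccc(Cl)cc1` also sits at a limit, > 25000 nM in this assay. The unmeasured compound 4 `Cc1ccccc1Nc1nc(C)c(C(=O)/C=C/c2ccccc2)s1` differs from compound 2 by hydrogen in place of chloro on an aromatic carbon. The nearest measured step runs the other way: an at least 1.0-fold higher number from compound 1 to compound 3 (0.00 log units; that floor lies within the scatter). The step that the two limits leave unreadable from compound 2 to compound 3 adds nothing readable. With two of three values at the limit (the limit of > 25000 nM in this assay, at which 2 of the 3 values shown sit), no movement beyond the scatter is expected, and the move is estimated as a step that the limit leaves unreadable from compound 2 to compound 4. Compound 4 is therefore expected near 30000 nM, within 12000 nM to 80000 nM.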

Compound 4, half-maximal inhibitory concentration: > 25000 nM
Compound 4: only a limit was reported; the forecaster's own chance of this, stated with the estimate: 60%; the middle value does not contradict the limit.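

In this assay compound 4 gives > 25000 nM, a limit and not a number. With 2-methylphenyl on the nitrogen, hydrogen in place of chloro on this aromatic carbon leaves the value at that limit, so the step between the two limits cannot be read. Among these compounds, the one readable new step, 2-methylphenyl in place of 4-chlorophenyl on the nitrogen, is an at least 1.0-fold higher number from compound 1 to compound 4 (0.00 log units; that floor lies within the scatter).

Going by these compounds, how far the compounds at the limit differ stays open: the limit of > 25000 nM in this assay, at which 3 of the 4 values shown sit. On these data alone, whether an amine or a carboxylic acid at this position would give a value short of the limit also stays open.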